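Notes on a non-aromatic sulfonyl substituent

This account rests on a few compounds, and the source may have more. Where it says the series, first, only, none or still open, it means among the compounds named here.

In a functional assay on A2780 cells (Homo sapiens) for cytotoxicity, read by sulforhodamine B assay, with a stated time of 72 h (on this read-out higher numbers stand for weaker inhibition and lower numbers for stronger inhibition), compound 3 (`O=C(NCc1ccc(S(=O)(=O)c2cc(F)cc(F)c2)cc1)N1Cc2ccncc2C1`) gives 6.3 nM, and compound 2 (`O=C(NCc1ccc(S(=O)(=O)c2cncc(C(F)(F)F)c2)cc1)N1Cc2ccncc2C1`) gives 10 nM; these two values lie within the scatter of each other. Compound 1 (`O=C(NCc1ccc(S(=O)(=O)c2ccccc2)cc1)N1Cc2cccnc2C1`) gives > 2000 nM, which is a limit of the assay.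

Compound 4 (`CCC(=O)N1CCC(S(=O)(=O)c2ccc(CNC(=O)N3Cc4ccncc4C3)cc2)CC1`) is still to be measured. It carries 1-propanoylpiperidin-4-yl in place of 3,5-difluorophenyl on a sulfonyl sulfur.

Within the data shown here, only one measured step bears on this site: a 1.6-fold lower number from compound 2 to compound 3 (0.20 log units; within the scatter). That step exchanges one aromatic group for another, so it gives only weak guidance for a non-aromatic ring. A modest move towards a higher number is expected, with an estimated 3.2-fold higher number from compound 3 to compound 4 (0.50 log units; beyond the scatter). Compound 4 is estimated at 20 nM, with an expected range of 5 nM to 90 nM.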

Compound 4, half-maximal inhibitory concentration: 54 nM
Compound 4: the middle estimate sits 2.7-fold (0.43 log units) below what was measured; measured number inside the range.
By their numbers in this assay, from the lowest: compounds 3 and 2 (each within the scatter of the next); then compound 4. At a limit, above all of these: compound 1.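

Putting a non-aromatic ring on the sulfonyl sulfur moves the number in this assay beyond the scatter: there is an 8.6-fold higher number from compound 3 to compound 4 (0.93 log units; beyond the scatter), and a 5.4-fold higher number from compound 2 to compound 4 (0.73 log units; beyond the scatter). Among these compounds, the two aromatic groups did not separate at this position, so 1-propanoylpiperidin-4-yl is the first group here to give a clear change. Nothing measured here bears on the reason for this change.

From the compounds shown here alone, it remains open whether the step follows from the non-aromatic ring or from the propanoyl group. A cyclohexyl ring and a piperidine with a free amine would separate these two parts.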